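Difluorination of the benzoyl group in the sulfoxide series

A few compounds are considered here, and "the series" means these few. Any claim that something is new, unique, unknown or untested is made for them only; others in the source may bear on it.

Measured compounds, with their values in an assay on membranes from striatum (strain Sprague-Dawley) for displacement of a labelled ligand from sodium-dependent dopamine transporter (Rattus norvegicus), read by scintillation counting, with a stated time of 120 min; on this read-out lower numbers stand for stronger inhibition and higher numbers for weaker inhibition:
compound 1, `OC(Cc1ccccc1)CN1CCC(NCCSC(c2ccc(F)cc2)c2ccc(F)cc2)CC1`, 31.4 nM
compound 2, `Fc1ccc(C(SCCNC2CCN(Cc3cc4ccccc4o3)CC2)c2ccc(F)cc2)cc1`, 120 nM
compound 3, `O=C(c1ccccc1)N1CCC(NCC[S+]([O-])C(c2ccc(F)cc2)c2ccc(F)cc2)CC1`, 79.1 nM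

Compound 3 gives the second highest of the three numbers in this assay; compound 2 sits nearest, within the scatter, and compound 1 lies furthest, a lower number beyond the scatter. The next compound, compound 4, is `O=C(c1ccc(F)cc1F)N1CCC(NCC[S+]([O-])C(c2ccc(F)cc2)c2ccc(F)cc2)CC1`. It differs from compound 3 by 2,4-difluorophenyl in place of phenyl on a carbonyl carbon.

Within the data shown here, the only measured step, a 3.8-fold higher number from compound 1 to compound 2 (0.58 log units; beyond the scatter), changes the group on the ring nitrogen, not the aryl of the carbonyl; no measured pair alters the benzoyl portion, so nothing speaks directly to this change. The usual outcome of adding two fluorines to an aryl ring of this kind, in the absence of a bearing step, is no shift beyond the scatter. For compound 4 the value in this assay is therefore expected to be 70 nM, with a range from 30 nM to 170 nM. The step from compound 3 to compound 4 is expected to be a 1.1-fold lower number from compound 3 to compound 4 (0.05 log units; within the scatter), within the scatter.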

Compound 4, inhibition constant: 564 nM
Estimate against measurement, compound 4: 8.1-fold (0.91 log units) below; measured number above the stated range.
By their numbers in this assay, from the lowest: compound 1; then compounds 3 and 2 (each within the scatter of the next); then compound 4.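

In this assay, among these compounds, the aryl on the carbonyl carbon is not a silent position: 2,4-difluorophenyl in place of phenyl gives a 7.1-fold higher number from compound 3 to compound 4 (0.85 log units; beyond the scatter), the first measured step at this place. The change enters only two fluorine atoms, with no hydrogen-bond donor or acceptor counted on either side, so even a small edit to the benzoyl portion can move the number beyond the scatter in the sulfoxide series. Nothing at hand accounts for the size or direction of this step.

From the compounds shown here alone, whether one fluorine alone would carry the step stays open, as does the outcome with a chlorine, a methoxy group or a pyridine ring in place of the phenyl on the carbonyl carbon. Also open, going by these compounds, is whether the same step would appear with a sulfide in place of the sulfoxide.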